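Cytotoxicity notes on the shared core: hydroxy for propyl

The source may hold more compounds than are shown below. What is called first, only, known or untested is meant among the compounds shown, and "the series" means these compounds.

The series shares one core: compound 1 is `CCc1c(F)c(N)c2c(=O)cc(-c3ccc(N)c(F)c3)oc2c1F`, compound 2 is `CCCCc1c(F)c(N)c2c(=O)cc(-c3ccc(N)c(F)c3)oc2c1F` and compound 3 is `C[S+]([O-])c1c(F)c(N)c2c(=O)cc(-c3ccc(N)c(F)c3)oc2c1F`. In a functional assay on HeLa cells (Homo sapiens) for cytotoxicity, read by neutral red uptake, with a stated time of 3 days (a higher number here means a weaker inhibitor, a lower number a stronger inhibitor), compound 1 gives > 100000 nM, which is a limit of the assay and not a number. In this assay compound 2 gives > 100000 nM, again a limit. In this assay compound 3 gives > 100000 nM, also a limit. Compound 2 thus stands where all three stand (the limit of > 100000 nM in this assay, at which 3 of the 3 values shown sit). The steps a step that the two limits leave unreadable from compound 1 to compound 2, a step that the two limits leave unreadable from compound 1 to compound 3 and a step that the two limits leave unreadable from compound 2 to compound 3 are each unreadable, both ends sitting at the limit.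

Compound 4 is `Nc1ccc(-c2cc(=O)c3c(N)c(F)c(CO)c(F)c3o2)cc1F`. It differs from compound 2 by hydroxy in place of propyl on a saturated chain carbon bound to an aromatic carbon. Within the data shown here, no measured step has a readable size, so none gives a direction; the three changes seen so far on this side of the core all left the value at the limit. Compound 4 is therefore expected to remain at the limit, and the step to compound 4 is expected to be a step that the limit leaves unreadable from compound 2 to compound 4. The estimate for compound 4 in this assay is 200000 nM, with a range of 100000 nM to 1000000 nM.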

Compound 4, half-maximal inhibitory concentration: 24000 nM
The estimate for compound 4 lay 8.3-fold (0.92 log units) above the measured number, outside the stated range (below it).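

This position on the shared core is not silent in this assay: butyl to hydroxymethyl gives an at least 4.1-fold lower number from compound 2 to compound 4 (0.61 log units; beyond the scatter), and the other two changes at this position give an at least 4.1-fold lower number from compound 1 to compound 4 (0.61 log units; beyond the scatter) and an at least 4.1-fold lower number from compound 3 to compound 4 (0.61 log units; beyond the scatter). Each of these steps has a limit at one end, so each size is a floor and not a measured difference, while the steps among compound 1, compound 2 and compound 3 cannot be read. The series therefore shows a first readable cytotoxic signal in compound 4 alone, with the other compounds still at the limit: the limit of > 100000 nM in this assay, at which 3 of the 4 values shown sit.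

Going by these compounds, whether the hydroxy itself is needed remains open, as no neighbouring group such as an amine or a carboxylic acid appears in its place. With a single compound off the limit, no trend along this position can be stated.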